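The source may hold more compounds than are shown below. What is called first, only, known or untested is meant among the compounds shown, and "the series" means these compounds.

In a functional assay on HCT-15 cells (Homo sapiens) for cytotoxicity, read by ELISA, with a stated time of 2 days (on this read-out lower numbers stand for stronger inhibition and higher numbers for weaker inhibition), compound 1 (`Oc1cccc(-c2cc(-c3ccccc3)cc(-c3cccc(O)c3)n2)c1`) gives 18400 nM and compound 2 (`Oc1cccc(-c2cc(-c3ccccc3)nc(-c3ccccc3)c2)c1`) gives 18000 nM, so compound 2 stands level with compound 1, within the scatter. Compound 3 (`Oc1cccc(-c2cc(-c3ccccc3)nc(-c3ccco3)c2)c1`) differs from compound 2 in one place: furan-2-yl in place of phenyl on an aromatic carbon. Within the data shown here, no measured pair shows such a change, so the expectation in this assay is of no step beyond the scatter, in either direction. The expected 1.2-fold lower number from compound 2 to compound 3 (0.08 log units; within the scatter) is therefore small. For compound 3 the estimated value is 15000 nM, with an expected range of 6000 nM to 40000 nM.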

Compound 3, half-maximal inhibitory concentration: 13900 nM
Estimate against measurement, compound 3: 1.1-fold (0.03 log units) above; measured number inside the range.
By their numbers in this assay, from the lowest: compounds 3, 2 and 1 (each within the scatter of the next).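

At this position, next to the ring nitrogen, furan-2-yl can take the place of phenyl in this assay with no step beyond the scatter: a 1.3-fold lower number from compound 2 to compound 3 (0.11 log units; within the scatter). Among these compounds, a five-membered aromatic ring with one hetero atom and one hydrogen-bond acceptor thus gives a number level with that of the six-membered carbon ring, which the earlier compounds could not show. No measurement at hand offers an explanation for this result. The compounds shown leave open whether an amine or a carboxylic acid on this carbon would give a step beyond the scatter.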